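The source may report more compounds than this note shows. Statements on the series, on what has been measured and on what is new or still open speak of the compounds shown alone.

Compound 1 `CC(C)[C@H](NC(=O)OCc1ccccc1)C(=O)N[C@@H](CO)C(=O)N[C@@H](CCCNC(=N)N)C(=O)CF` gives 290 nM in a functional assay on OCI-Ly3 cells (Homo sapiens) for inhibition, read by CellTiter-Glo, with stated times of 48 h and 96 h; on this read-out higher numbers stand for weaker inhibition of growth and lower numbers for stronger inhibition of growth. Compound 2 `CC(C)[C@H](NC(=O)OCc1ccccc1)C(=O)N1C[C@H](O)C[C@H]1C(=O)N[C@@H](CCCNC(=N)N)C(=O)CF` gives 290 nM in this assay. Compound 3 `CC(C)[C@H](NC(=O)c1ccc(Br)cc1)C(=O)N[C@@H](CO)C(=O)N[C@@H](CCCNC(=N)N)C(=O)CF` gives 150 nM in this assay.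

Compound 3 differs from compound 1 in one place: 4-bromophenyl in place of benzyloxy on a carbonyl carbon. In this assay this change gave a 1.9-fold lower number from compound 1 to compound 3 (0.29 log units; within the scatter). Compound 2 and compound 1 rest on two different cores; how those cores differ is not broken down here. In this assay the two show the same number at the digits printed, within the scatter of one another.

Compound 4 `CC(C)[C@H](NC(=O)c1ccc(Br)cc1)C(=O)N1C[C@H](O)C[C@H]1C(=O)N[C@@H](CCCNC(=N)N)C(=O)CF` is not yet measured. It stands to compound 2 as compound 3 stands to compound 1, the same change in the same place: 4-bromophenyl in place of benzyloxy on a carbonyl carbon. Because the earlier step was a 1.9-fold lower number from compound 1 to compound 3 (0.29 log units; within the scatter), a step of about the same size, a 1.8-fold lower number from compound 2 to compound 4 (0.26 log units; within the scatter), is expected for compound 4 in this assay. The estimate for compound 4 is 160 nM, expected to lie between 70 nM and 350 nM.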

Compound 4, concentration for 50% growth inhibition: 70 nM
Beside the measured number, compound 4's estimate is 2.3-fold (0.36 log units) above it; measured number inside the range.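

Carried to the other core, 4-bromophenyl in place of benzyloxy gave a 4.1-fold lower number from compound 2 to compound 4 (0.62 log units; beyond the scatter) in this assay. Set beside the earlier step, this one cannot be told apart from it in size: the same change on two cores in this assay, a 1.9-fold lower number (0.29 log units; within the scatter) from compound 1 to compound 3 and a 4.1-fold lower number (0.62 log units; beyond the scatter) from compound 2 to compound 4, 2.1-fold (0.33 log units) apart, within the scatter of two such steps

Going by these compounds alone, the result is consistent with the change carrying over between these two cores, but only the step on the core of compound 2 lies beyond the scatter on its own, and two cores cannot show that it would hold on any other core. The compounds shown leave open how other groups on this carbonyl carbon would read, such as plain phenyl, 4-chlorophenyl or a longer chain. They also leave open whether the bromine matters at all.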